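A Butyl Chain on the Benzoyl of Compound 1

The source may report more compounds than this note shows. Statements on the series, on what has been measured and on what is new or still open speak of the compounds shown alone.

Measured compounds:
compound 1 `CCCC(=O)N1CCC(NS(=O)(=O)c2ccc(NC(=O)c3ccccc3)c3ccccc23)CC1` gives 12.5 nM
compound 2 `CCCC(=O)N1CCC(NS(=O)(=O)c2ccc(NC(=O)c3cccc(C)c3)c3ccccc23)CC1` gives 5.1 nM
compound 3 `CCCC(=O)N1CCC(NS(=O)(=O)c2ccc(NC(=O)c3ccc(C)cc3)c3ccccc23)CC1` gives 9.5 nM

In an in vitro functional assay on CHO/Galpha16 cells for antagonist activity at C-C chemokine receptor type 8 (Homo sapiens), read by FLIPR (a higher number here means a weaker inhibitor, a lower number a stronger inhibitor), compound 1 stands with the highest number of the three. Its nearest neighbour is compound 3, and the step of a 1.3-fold lower number from compound 1 to compound 3 (0.12 log units; within the scatter) stays within the scatter. Among the measured compounds shown here, the furthest is compound 2, reached by a 2.5-fold lower number from compound 1 to compound 2 (0.39 log units; beyond the scatter), the only step among the three that goes beyond the scatter; between compound 2 and compound 3 the step of a 1.9-fold higher number from compound 2 to compound 3 (0.27 log units; within the scatter) is again within the scatter.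

Compound 4 `CCCCc1ccc(C(=O)Nc2ccc(S(=O)(=O)NC3CCN(C(=O)CCC)CC3)c3ccccc23)cc1` is compound 1 with a single change: butyl in place of hydrogen on an aromatic carbon. The step bearing most directly on it is that from compound 1 to compound 3, where a methyl enters the same ring and the number hardly moves. For the measured compounds named here, no measured compound carries a chain longer than methyl on this ring, so the effect of the four-carbon butyl is not covered by the data. The step from compound 1 to compound 2 shows that a methyl elsewhere on this ring can lower the number beyond the scatter, but that is a different place.

Compound 4 is therefore expected to give a number close to that of compound 1, with a step of a 1.4-fold lower number from compound 1 to compound 4 (0.14 log units; within the scatter) that need not exceed the scatter. The estimate for compound 4 in this assay is 9 nM, with a range from 3 nM to 30 nM.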

Compound 4, half-maximal inhibitory concentration: 15.3 nM
Beside the measured number, compound 4's estimate is 1.7-fold (0.23 log units) below it; low and high end bracket the measured number.
By their numbers in this assay, from the lowest: compounds 2, 3, 1 and 4 (each within the scatter of the next, the first and the last beyond it).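

In this assay, the place para to a large group on the benzoyl ring accepts a full butyl chain as readily as it accepts methyl: a 1.2-fold higher number from compound 1 to compound 4 (0.09 log units; within the scatter) stays within the scatter, so the earlier result for methyl extends to a much longer chain. Going from methyl to butyl at this place, a 1.6-fold higher number from compound 3 to compound 4 (0.21 log units; within the scatter) is also within the scatter, so compound 1, compound 3 and compound 4 together show no dependence of the number on chain length from hydrogen up to butyl. Among the compounds shown here, the one new step beyond the scatter, a 3.0-fold higher number from compound 2 to compound 4 (0.48 log units; beyond the scatter), replaces 3-methylphenyl with 4-butylphenyl and so alters both the place and the chain at once, which means it cannot be assigned to either change alone.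

Nothing among the data shown accounts for why the number holds steady across these chains. Still open, as far as these compounds go, are whether butyl on the ring carbon that carries the methyl of compound 2 would keep the lower number of that compound, and whether a longer chain, or a chain ending in an amine or a carboxylic acid, at the place of the butyl would move the number beyond the scatter.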